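This account rests on a few compounds, and the source may have more. Where it says the series, first, only, none or still open, it means among the compounds named here.

Measured in a functional assay on MCF7 cells (Homo sapiens) for antiproliferative activity; a lower number here means a stronger inhibitor, a higher number a weaker inhibitor:
- Compound 1 `Nc1ccc(-c2nc3ccccc3s2)cc1I` gives < 1 nM
- Compound 2 `O=C(CCl)Nc1ccc(-c2nc3ccccc3s2)cc1` gives > 10 nM

Both values are limits of the assay, not numbers. Compound 2 has only its limit (of > 10 nM) in this assay, so its true position is not known.

Compound 3 `O=C(CCl)Nc1ccc(-c2nc3ccccc3s2)cc1I` keeps the ((chloromethyl)carbonyl)amino group of compound 2 and has iodo in place of hydrogen on an aromatic carbon, ortho to that group (see (iodo in place of hydrogen on an aromatic carbon)).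

For the measured compounds named here, no measured pair in this set isolates this change. The expectation rests on compound 1, which also carries the iodo group and shows the limit < 1 nM in this series. A moderate move towards stronger inhibition is therefore expected for the step of an at least 2.5-fold lower number from compound 2 to compound 3 (0.39 log units; beyond the scatter), though its size is uncertain. For compound 3 the estimated value is 4 nM (expected range 0.5 nM to 30 nM).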

Compound 3, half-maximal inhibitory concentration: > 10 nM
Compound 3: no number, only a limit; the forecaster's own chance of this, stated with the estimate: 40%; middle value at least 2.5-fold (0.39 log units) away from the limit.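

In this assay compound 3 gives > 10 nM, a limit of the assay. Compound 2 stands at the same limit, so the step for iodo in place of hydrogen on this aromatic carbon, ortho to a ((chloromethyl)carbonyl)amino group, cannot be read. The readable change is (chloromethyl)carbonyl in place of hydrogen on the nitrogen, with iodo kept in both compounds, which gives an at least 10-fold higher number from compound 1 to compound 3 (1.00 log units; beyond the scatter), so iodo alone does not keep a compound at the strong end of this set.

As far as these compounds go, how far compound 2 and compound 3 each lie beyond that limit stays open: the limit of > 10 nM in this assay, at which 2 of the 3 values shown sit. Also open, from the compounds shown here alone, is whether a smaller acetyl group on the nitrogen, or bromo in place of iodo, would retain the strength of compound 1.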